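A few compounds are considered here, and "the series" means these few. Any claim that something is new, unique, unknown or untested is made for them only; others in the source may bear on it.

Measured in a functional assay on HCT-116 cells (Homo sapiens) for cytotoxicity, read by hypoxanthine incorporation, with a stated time of 72 h, tested at 10 uM; on this read-out higher numbers stand for more inhibition of growth at the one concentration tested and lower numbers for less inhibition of growth:

compound 1 `CC(C)C[C@@H]1NC(=O)[C@H](CCCN/C(=N/C(=O)OCc2ccccc2)NC(=O)OCc2ccccc2)NC(=O)[C@H](C(C)C)NC(=O)[C@H](CC(C)C)NC(=O)[C@@H](Cc2ccc(O)cc2)NC1=O` gives 2%
compound 2 `CC(C)C[C@H]1C(=O)N[C@@H](CCCCNC(=O)OC(C)(C)C)C(=O)N[C@@H](Cc2ccccc2)C(=O)N(C)[C@H](Cc2ccccc2)C(=O)N[C@@H](C(C)C)C(=O)N1C` gives 36%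
compound 3 `CC(C)C[C@@H]1NC(=O)[C@H](Cc2ccccc2)NC(=O)[C@H](CCCCNC(=O)OC(C)(C)C)NC(=O)[C@H](CC(C)C)NC(=O)[C@H](C(C)C)NC1=O` gives 0%

Compound 3 (0%) sits within the scatter of compound 1 (2%), so these two cannot be told apart. Compound 2 (36%) lies well beyond the scatter above both.

The next compound to be tested, compound 4 `CC(C)C[C@@H]1NC(=O)[C@H](Cc2ccccc2)NC(=O)[C@H](CCCCNC(=O)OC(C)(C)C)N(C)C(=O)[C@H](CC(C)C)NC(=O)[C@H](C(C)C)NC1=O`, differs from compound 3 at a single place: methyl in place of hydrogen on an amide-type nitrogen in a ring. Methyl takes the place of hydrogen on an amide-type nitrogen in a ring, next to the ring atom that bears a 4-((tert-butoxycarbonyl)amino)butyl group.

Going by the values given here, no measured pair shows this change on its own, so the guide is weak. Among the compounds with values here, compound 2 (36%) is the only measured compound that also has methyl on such a nitrogen, which hints at a rise rather than a fall. In this assay the expected size of the step of a number 8 percentage points higher from compound 3 to compound 4 (within the scatter) is small, a rise that probably stays within the scatter. For compound 4 the estimated value is 8%, with an expected range from 0% to 30%.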

Compound 4, percent growth inhibition at one concentration: 58%
Compound 4: the middle estimate sits 50 percentage points below what was measured, outside the stated range (above it).
By their numbers in this assay, from the lowest: compounds 3 and 1 (each within the scatter of the next); then compound 2; then compound 4.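

In this assay, methyl in place of the amide hydrogen on this ring nitrogen, next to the ring atom that bears a 4-((tert-butoxycarbonyl)amino)butyl group, gives a number 58 percentage points higher from compound 3 to compound 4 (beyond the scatter), so at this position this one small change is enough to move the read-out well beyond the scatter. The earlier compounds shown here could not show this, since no two of them differed in one place only. Nothing measured here explains why the step is so large.

Going by these compounds, whether ethyl or a longer chain on this same nitrogen would do the same, and whether methyl on the other ring nitrogens would, stays open. Also open, on these data alone, is what a free amine at the end of the side chain, in place of the tert-butoxycarbonyl-protected one, would give in this assay.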